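The compounds below may be only part of what the source reports. "The series", "measured", "known", "first", "only" and "open" are said of these compounds alone.

Series notes. The shared core of compound 1 `C(#Cc1ccccn1)C1=CCCC1` carries a five-membered unsaturated ring; compound 2 `C(#Cc1ccccn1)C1=CC(Sc2ccc3ccccc3c2)CCC1` and compound 3 `C(#Cc1ccccn1)C1=CC(Sc2ccncc2)CCC1` instead carry a six-membered non-aromatic ring bearing a sulfanyl-linked aromatic group on a saturated ring carbon. In an assay for displacement of a labelled ligand from metabotropic glutamate receptor 5 (Rattus norvegicus) (a higher number here means a weaker inhibitor, a lower number a stronger inhibitor), compound 1 gives 10 nM, compound 2 gives 75 nM and compound 3 gives 43 nM. Compound 3 thus holds the second highest of the three numbers; its gap to compound 2 lies within the scatter, while compound 1 sits at a lower number, beyond the scatter.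

Compound 4 `C(#Cc1ccccn1)C1=CC(Nc2cccnc2)CCC1` differs from compound 3 in one place: (pyridin-3-yl)amino in place of (pyridin-4-yl)sulfanyl on a saturated ring carbon. For the measured compounds named here, no pair of measured compounds shows this change, so its size is open. Both sulfanyl-linked compounds in this assay sit within the scatter of each other, which gives no reason to expect a large departure from compound 3. Compound 4 is therefore expected to give 50 nM in this assay, with a range of 15 nM to 200 nM. The expected step from compound 3 to compound 4 is a 1.2-fold higher number from compound 3 to compound 4 (0.07 log units; within the scatter), no larger than the scatter in either direction.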

Compound 4, inhibition constant: 7.3 nM
Compound 4: middle estimate off by 6.8-fold (0.84 log units), on the high side; the measured number lies below the stated range.
By their numbers in this assay, from the lowest: compounds 4 and 1 (each within the scatter of the next); then compounds 3 and 2 (each within the scatter of the next).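

In this assay, the saturated ring carbon responds to what is attached there: (pyridin-3-yl)amino in place of (pyridin-4-yl)sulfanyl gives a 5.9-fold lower number from compound 3 to compound 4 (0.77 log units; beyond the scatter), a step beyond the scatter. The two groups match in heavy-atom count and each holds a six-membered aromatic ring, but the swap changes the linking atom and the pyridine attachment point together, and the entering group adds a hydrogen-bond donor, so the step belongs to the combined change. Nothing available explains the size of this step.

Which part of the change carries the step remains open; a (pyridin-3-yl)sulfanyl or a (pyridin-4-yl)amino group at this carbon would separate the two. Also open, going by these compounds, is how the number would respond to an ether oxygen link or a methylated amino link.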